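The compounds below may be only part of what the source reports. "The series", "measured", "known", "first", "only" and "open" are said of these compounds alone.

Measured in an ADME assay on PA-1 cells (Homo sapiens) for cytotoxicity, read by MTT assay, with a stated time of 72 h; a lower number here means a stronger inhibitor, a higher number a weaker inhibitor:
Compound 1 `COc1ccc(C2=C(c3cc(OC)c(OC)c(OC)c3)C(=O)C(OC(C)=O)C2)cc1OC(C)C`: > 100 ug/mL, a limit of the assay
Compound 2 `COc1ccc(C2=C(c3cc(OC)c(OC)c(OC)c3)C(=O)C(OC(C)=O)C2)cc1Cl`: > 100 ug/mL, a limit of the assay

Compound 2 has no exact figure of its own. Compound 2 stands at > 100 ug/mL, which is a limit and not a number. Compound 1 shares that position, so the evidence so far consists of the limit of > 100 ug/mL in this assay, at which 2 of the 2 values shown sit.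

The next compound, compound 3 `COc1ccc(C2=C(c3cc(OC)c(OC)c(OC)c3)C(=O)C(OC(C)=O)C2)cc1O`, keeps the core of compound 2 and changes one group: hydroxy in place of chloro on an aromatic carbon. This is hydroxy in place of chloro on an aromatic carbon, taking 3-chloro-4-methoxyphenyl to 3-hydroxy-4-methoxyphenyl.

Among the measured compounds shown here, only one measured step bears on this change: a step that the two limits leave unreadable from compound 1 to compound 2. It also replaces a group on an aromatic carbon, but it offers no size to carry over. In this assay, the only readable result would be a move towards stronger inhibition, and its size cannot be predicted from these data. Compound 3 may well remain at the limit, so the expectation is held loosely. The expected change is an at least 2.5-fold lower number from compound 2 to compound 3 (0.39 log units; beyond the scatter). For compound 3 the estimated value is 40 ug/mL, within an expected range from 2 ug/mL to 120 ug/mL.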

Compound 3, half-maximal inhibitory concentration: 6 ug/mL
Compound 3: the middle estimate sits 6.7-fold (0.82 log units) above what was measured; the measured number falls inside the stated range.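

In this assay, among the compounds shown here, the group at this position on the aromatic ring turns out to decide whether any readable activity appears at all, which neither of the earlier compounds could show. Setting hydroxy in place of chloro gives an at least 16-fold lower number from compound 2 to compound 3 (1.22 log units; beyond the scatter), and setting hydrogen in place of isopropyl on the oxygen gives an at least 16-fold lower number from compound 1 to compound 3 (1.22 log units; beyond the scatter), so the free hydroxy group separates compound 3 from both compound 1 and compound 2 by a large step, beyond the scatter, along two different single changes. Both steps start from a limit of the assay, so each gives only a minimum size and the full size remains unknown: the limit of > 100 ug/mL in this assay, at which 2 of the 3 values shown sit.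

The step from compound 1 to compound 2 cannot be read, which leaves the chloro and isopropoxy groups unranked against each other. The compounds shown also leave open whether an amine or a carboxylic acid in the same place would keep the number of compound 3, and whether a methoxy group there, with only the hydrogen of the hydroxy group replaced by methyl, would already lose it.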